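A few compounds are considered here, and "the series" means these few. Any claim that something is new, unique, unknown or untested is made for them only; others in the source may bear on it.

In an ADME assay on microsomes from liver (Mus musculus) for metabolic stability, read by LC-MS (on this read-out lower numbers stand for a shorter-lived compound and higher numbers for a longer-lived compound), compound 2 `O=C(Nc1ccc(F)c(-c2nc3ncc(-c4ccc(F)cc4)cc3[nH]2)c1)N1CCCC1` gives 0.095 h and compound 1 `O=C(Nc1ccc(F)c(-c2nc3ncc(-c4ccc(F)c(F)c4)cc3[nH]2)c1)N1CCCC1` gives 0.08 h, so the two values lie within the scatter of each other. Compound 3 `Cc1nc(C)c(C(=O)Nc2ccc(F)c(-c3nc4ncc(-c5ccccc5Cl)cn4n3)c2)o1`, built on a different core, gives > 1.5 h, which is a limit of the assay and not a number. Compound 4 `O=C(Nc1ccc(F)c(-c2nc3ncc(-c4cccc(F)c4)cc3[nH]2)c1)N1CCCC1` differs from compound 2 in one place: 3-fluorophenyl in place of 4-fluorophenyl on an aromatic carbon. The same atoms are present, but 3-fluorophenyl stands in place of 4-fluorophenyl. Among the measured compounds shown here, the one measured step on this group is a 1.2-fold higher number from compound 1 to compound 2 (0.07 log units; within the scatter), where hydrogen replaces fluoro, and it stays within the scatter. No step beyond the scatter is therefore expected in this assay. The estimated step is a 1.1-fold lower number from compound 2 to compound 4 (0.02 log units; within the scatter). Compound 4 is expected at 0.09 h, with an estimated range of 0.05 h to 0.17 h.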

Compound 4, half-life: 0.0833 h
For compound 4 the middle estimate is 1.1-fold (0.03 log units) above the measured one, and the stated range covers the measured number.
By their numbers in this assay, from the lowest: compounds 1, 4 and 2 (each within the scatter of the next). At a limit, above all of these: compound 3.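

In this assay, 3-fluorophenyl in place of 4-fluorophenyl gives a 1.1-fold lower number from compound 2 to compound 4 (0.06 log units; within the scatter), and the comparison with the extra fluoro of compound 1 gives a 1.0-fold higher number from compound 1 to compound 4 (0.02 log units; within the scatter). The earlier compounds shown here showed only that a fluoro could be added or removed within the scatter; the new result shows the same for where a single fluoro sits on this phenyl ring. The data shown give no reason for this closeness. As far as these compounds go, whether a methoxy group or a nitrile on this phenyl ring, or an amine in its place, would shift the half-life beyond the scatter stays open.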